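Swapping the Aryl Group on the Nitrogen of Compound 3

This account rests on a few compounds, and the source may have more. Where it says the series, first, only, none or still open, it means among the compounds named here.

Compound 3 `CNC(=O)c1cc(Oc2ccc(NC(=O)c3cc4cccnc4n(-c4ccc(C(F)(F)F)cc4Cl)c3=O)cc2)ccn1` stands highest of the three measured numbers in a functional assay on HT-29 cells (Homo sapiens) for antiproliferative activity, read by MTT assay, with a stated time of 72 h (on this read-out higher numbers stand for weaker inhibition and lower numbers for stronger inhibition), giving 3190 nM. Compound 1 `CNC(=O)c1cc(Oc2ccc(NC(=O)c3cc4cccnc4n(-c4ccccc4)c3=O)cc2)ccn1` gives 250 nM and compound 2 `CNC(=O)c1cc(Oc2ccc(NC(=O)c3cc4cccnc4n(-c4ccc(Br)cc4)c3=O)cc2)ccn1` gives 1180 nM in this assay; the steps of a 13-fold higher number from compound 1 to compound 3 (1.11 log units; beyond the scatter) and a 2.7-fold higher number from compound 2 to compound 3 (0.43 log units; beyond the scatter) both place the movement at the aryl group on the aromatic nitrogen. Compound 4 `CNC(=O)c1cc(Oc2ccc(NC(=O)c3cc4cccnc4n(-c4ccc(F)c(Cl)c4)c3=O)cc2)ccn1` carries 3-chloro-4-fluorophenyl in place of 2-chloro-4-(trifluoromethyl)phenyl on an aromatic nitrogen. The step of a 2.7-fold higher number from compound 2 to compound 3 (0.43 log units; beyond the scatter) bears most closely on it, since compound 2 and compound 4 both carry a halogen-bearing phenyl, while a 4.7-fold higher number from compound 1 to compound 2 (0.67 log units; beyond the scatter) shows that a single bromo already raises the number. Compound 4 is therefore expected to show a step of a 2.1-fold lower number from compound 3 to compound 4 (0.33 log units; beyond the scatter), landing between the numbers of compound 2 and compound 3. The estimate for compound 4 in this assay is 1500 nM, ranging from 500 nM to 4500 nM.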

Compound 4, half-maximal inhibitory concentration: 1810 nM
Compound 4: middle estimate off by 1.2-fold (0.08 log units), on the low side, and the stated range covers the measured number.
By their numbers in this assay, from the lowest: compound 1; then compounds 2, 4 and 3 (each within the scatter of the next, the first and the last beyond it).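

In this assay, compound 4 cannot be told apart from either of its substituted neighbours, with a 1.8-fold lower number from compound 3 to compound 4 (0.25 log units; within the scatter) and a 1.5-fold higher number from compound 2 to compound 4 (0.19 log units; within the scatter), even though compound 2 and compound 3 lie beyond the scatter of each other. Only the unsubstituted phenyl of compound 1 stands clearly apart, with a 7.2-fold higher number from compound 1 to compound 4 (0.86 log units; beyond the scatter), so all three halogen-bearing aryl groups shown give weaker inhibition than phenyl. Nothing measured here accounts for this. From the compounds shown here alone, whether an amine or a carboxylic acid on this phenyl would hold the number of compound 1 remains open.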